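Branched alkyl in place of benzyl: expectation for compound 4

A few compounds are considered here, and "the series" means these few. Any claim that something is new, unique, unknown or untested is made for them only; others in the source may bear on it.

In an in vitro functional assay on cells for agonist activity at Bombesin receptor subtype-3 (Mus musculus), read by luminescence and calcium flux (on this read-out higher numbers stand for an effect only at larger amounts of compound and lower numbers for an effect already at smaller amounts), compound 3 `O=C(O)c1ccccc1-c1ccc(CCc2ncc(CCc3ccccc3)[nH]2)cc1` gives 174 nM, the highest number among the three measured compounds; compound 2 `Cc1ccccc1Cc1cnc(CCc2ccc(-c3ccccc3C(=O)O)cc2)[nH]1` gives 9.3 nM and compound 1 `O=C(O)c1ccccc1-c1ccc(CCc2ncc(CC3CCC3)[nH]2)cc1` gives 7.1 nM. Compound 4 `CCC(C)(CC)Cc1cnc(CCc2ccc(-c3ccccc3C(=O)O)cc2)[nH]1` differs from compound 3 by 1-ethyl-1-methylpropyl in place of benzyl on a saturated chain carbon bound to an aromatic carbon. The measured steps that bear on this place are a 25-fold higher number from compound 1 to compound 3 (1.39 log units; beyond the scatter) and a 19-fold higher number from compound 2 to compound 3 (1.27 log units; beyond the scatter), whereas a 1.3-fold higher number from compound 1 to compound 2 (0.12 log units; within the scatter). Both groups other than benzyl at this place gave markedly lower numbers, and the entering 1-ethyl-1-methylpropyl, like cyclobutyl, carries no aromatic ring. A large step downward is therefore expected for compound 4, a 12-fold lower number from compound 3 to compound 4 (1.06 log units; beyond the scatter). Compound 4 is estimated at 15 nM, with a range of 4 nM to 60 nM.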

Compound 4, half-maximal effective concentration: 30 nM
Compound 4: middle estimate off by 2.0-fold (0.30 log units), on the low side; low and high end bracket the measured number.
By their numbers in this assay, from the lowest: compounds 1 and 2 (each within the scatter of the next); then compound 4; then compound 3.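

With no ring at all, 1-ethyl-1-methylpropyl still gives a 5.8-fold lower number from compound 3 to compound 4 (0.76 log units; beyond the scatter), so a number below that of compound 3 at this place needs neither the aromatic ring of compound 2 nor the saturated ring of compound 1. The open-chain group does not match either ring-bearing group, however, with a 3.2-fold higher number from compound 2 to compound 4 (0.51 log units; beyond the scatter) and a 4.2-fold higher number from compound 1 to compound 4 (0.63 log units; beyond the scatter). Nothing available accounts for this order.

Still open, on these data alone, is how an amine or a hydroxyl group at this place would read out. As far as these compounds go, a longer unbranched chain in place of 1-ethyl-1-methylpropyl is equally open.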